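Nitro for Chloro on the Anilide Ring of Compound 2

A few compounds are considered here, and "the series" means these few. Any claim that something is new, unique, unknown or untested is made for them only; others in the source may bear on it.

Compound 1, `COc1cc2c(cc1OC)C(CC(=O)Nc1cccc(Cl)c1)CC2`: 31.3%
Compound 2, `COc1cc2c(cc1OC)C(CC(=O)Nc1ccc(Cl)cc1)CC2`: 71.9%
Compound 3, `COc1cc2c(cc1OC)C(CC(=O)Nc1cccc(C)c1)CC2`: 37.5%

In a functional assay on the whole organism (strain Wistar) for inhibition, with Rattus norvegicus as the target, read by paw edema, with a stated time of 1 h, at a dose of 100 mg/kg (a higher number here means more inhibition at the dose given (going by the name of the read-out), a lower number less inhibition), compound 2 stands highest of the three measured compounds; compound 3 comes nearest, a number 34.4 percentage points lower from compound 2 to compound 3 (beyond the scatter), and compound 1 lies furthest, a number 40.6 percentage points higher from compound 1 to compound 2 (beyond the scatter). Compound 4, `COc1cc2c(cc1OC)C(CC(=O)Nc1ccc([N+](=O)[O-])cc1)CC2`, differs from compound 2 by nitro in place of chloro on an aromatic carbon.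

Within the data shown here, none of the measured steps exchanges a group at this same carbon, so the evidence is indirect. a number 40.6 percentage points higher from compound 1 to compound 2 (beyond the scatter) shows that moving a chloro from one carbon of the ring to another shifts the read-out far, while a number 6.2 percentage points higher from compound 1 to compound 3 (within the scatter) shows that exchanging one group for another at the same carbon leaves the number within the scatter. Both steps carry a chloro and neither involves a nitro, so the direction for compound 4 is open. The author therefore expects for compound 4 a step of a number 13.9 percentage points lower from compound 2 to compound 4 (beyond the scatter), a modest lowering that may well stay within the scatter, with a wide range. Compound 4 is estimated at 58%, between 30% and 80%.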

Compound 4, a percentage reported as inhibition, in the whole organism at one dose (the size of the read-out at that dose, not a potency): 37.5%
Beside the measured number, compound 4's estimate is 20.5 percentage points above it; measured number inside the range.
By their numbers in this assay, from the lowest: compounds 1, 3 and 4 (each within the scatter of the next); then compound 2.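

At the carbon para to a large group, the step from chloro to nitro in this assay is a number 34.4 percentage points lower from compound 2 to compound 4 (beyond the scatter), so the high number of compound 2 depends on which group sits at this carbon and not merely on a group being there. Among these compounds, the earlier compounds showed a large shift only when the chloro changed carbon, as a number 40.6 percentage points higher from compound 1 to compound 2 (beyond the scatter) records, while the one exchange of groups at a single carbon, a number 6.2 percentage points higher from compound 1 to compound 3 (within the scatter), stayed within the scatter; this is the first exchange at one carbon that moves the number beyond it. Nothing available explains why this exchange has so large an effect.

The compounds shown leave open how methyl, fluoro, methoxy or an amine at this carbon would read in this assay and whether any of them would match chloro. They also leave open whether the step from chloro to nitro would be as large at another dose or at another time.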